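From 4-chlorobenzyl to 2,4-difluorobenzyl

The source may hold more compounds than are shown below. What is called first, only, known or untested is meant among the compounds shown, and "the series" means these compounds.

- Compound 1 `C=C1C(=O)O[C@H]2[C@H]1CC/C(COC(=O)CCC(=O)NCCCCCCNC(=O)Cn1cc(F)c(=O)n(Cc3ccccc3)c1=O)=C\CC[C@@]1(C)O[C@@H]21`: 16200 nM
- Compound 2 `C=C1C(=O)O[C@H]2[C@H]1CC/C(COC(=O)CCC(=O)N1CCN(C(=O)Cn3cc(F)c(=O)n(Cc4ccccc4)c3=O)CC1)=C\CC[C@@]1(C)O[C@@H]21`: > 20000 nM
- Compound 3 `C=C1C(=O)O[C@H]2[C@H]1CC/C(COC(=O)Cn1cc(F)c(=O)n(Cc3ccc(Cl)cc3)c1=O)=C\CC[C@@]1(C)O[C@@H]21`: 2420 nM

All three compounds were tested in a functional assay on Bel7402/5-FU cells (Homo sapiens) for antiproliferative activity, read by MTT assay, with a stated time of 72 h; a higher number here means a weaker inhibitor, a lower number a stronger inhibitor. The entry for compound 2, > 20000 nM, is a limit of the assay and not a number. Compound 3, at 2420 nM, has the lowest number shown. Its nearest neighbour, compound 1 at 16200 nM, lies beyond the scatter from it.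

Compound 4 `C=C1C(=O)O[C@H]2[C@H]1CC/C(COC(=O)Cn1cc(F)c(=O)n(Cc3ccc(F)cc3F)c1=O)=C\CC[C@@]1(C)O[C@@H]21` keeps the shared core of compound 3 and alters one group: 2,4-difluorophenyl in place of 4-chlorophenyl on a saturated chain carbon bound to an aromatic nitrogen. In words, 2,4-difluorophenyl stands in place of 4-chlorophenyl on a saturated chain carbon bound to an aromatic nitrogen. Within the data shown here, no two measured compounds differ in one place only, so the expectation starts from compound 3 at 2420 nM and stays cautious. Only a small rise in the number is expected in this assay, no larger than the scatter. The estimated change is a 1.4-fold higher number from compound 3 to compound 4 (0.16 log units; within the scatter). For compound 4 the estimated value is 3500 nM, with an expected range of 1200 nM to 10000 nM.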

Compound 4, half-maximal inhibitory concentration: 5010 nM
The estimate for compound 4 lay 1.4-fold (0.16 log units) below the measured number; measured number inside the range.
By their numbers in this assay, from the lowest: compound 3; then compound 4; then compound 1. At a limit, above all of these: compound 2.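

In this assay the swap of 4-chlorophenyl for 2,4-difluorophenyl gives a 2.1-fold higher number from compound 3 to compound 4 (0.32 log units; beyond the scatter) and so marks a modest loss of activity. This is the first pair among the compounds shown that differs in one place only, so it gives the first direct sign that the aromatic ring on a saturated chain carbon bound to an aromatic nitrogen influences the result, although this change costs little. Nothing among the available data explains the step.

A single swap cannot separate the effect of losing chlorine from that of gaining fluorine, since both happen together here. Going by these compounds, it also remains open how this position would respond to a quite different group, such as a methoxyphenyl, a pyridine ring or a plain methyl group.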